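Changing the Amide Side Chain of Compound 1

The source may hold more compounds than are shown below. What is called first, only, known or untested is meant among the compounds shown, and "the series" means these compounds.

In an in vitro ADME assay on microsomes from liver (Homo sapiens) for metabolic stability, using NADPH (on this read-out higher numbers stand for fast clearance and lower numbers for slow clearance), compound 1 `CC(C)(CO)CNC(=O)c1cc2cc(C#N)ccc2n1Cc1cccc(OC(F)(F)F)c1` gives 62 mL.min-1.g-1, the lower of the two numbers available. Among the measured compounds shown here, the only other measured compound, compound 2 `CCCOc1cccc(Cn2c(C(=O)NCC(C)(C)CO)cc3cc(C#N)ccc32)c1`, gives 156 mL.min-1.g-1. Compound 3 `N#Cc1ccc2c(c1)cc(C(=O)NCCC1(O)CCC1)n2Cc1cccc(OC(F)(F)F)c1` has not yet been measured. It keeps the core of compound 1 and differs from it as follows: (1-hydroxycyclobutyl)methyl in place of 1-(hydroxymethyl)-1-methylethyl on a saturated chain carbon bound to an amide-type nitrogen. In short, (1-hydroxycyclobutyl)methyl stands in place of 1-(hydroxymethyl)-1-methylethyl on a saturated chain carbon bound to an amide-type nitrogen.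

For the measured compounds named here, the one measured step, a 2.5-fold higher number from compound 1 to compound 2 (0.40 log units; beyond the scatter), comes with propyl in place of trifluoromethyl on an oxygen on an aromatic ring. That is a different place from the new change, so this step bears on it only indirectly, as a guide to how large a modest step looks in this assay. Going by the values given here, no measured step involves the chain on the amide nitrogen. No change beyond the scatter is therefore expected, though a step of similar size in either direction remains possible. The expected step is a 1.1-fold higher number from compound 1 to compound 3 (0.05 log units; within the scatter). For compound 3 the estimated value is 70 mL.min-1.g-1, with an expected range from 32 mL.min-1.g-1 to 150 mL.min-1.g-1.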

Compound 3, intrinsic clearance in microsomes: 78 mL.min-1.g-1
Beside the measured number, compound 3's estimate is 1.1-fold (0.05 log units) below it, within the range that was stated.
By their numbers in this assay, from the lowest: compounds 1, 3 and 2 (each within the scatter of the next, the first and the last beyond it).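

In this assay, among the compounds shown here, the first measured exchange on a saturated chain carbon bound to an amide-type nitrogen, (1-hydroxycyclobutyl)methyl in place of 1-(hydroxymethyl)-1-methylethyl, gives a 1.3-fold higher number from compound 1 to compound 3 (0.10 log units; within the scatter), even though the entering group brings in a four-membered non-aromatic ring of carbon only. Both groups carry 1 hydrogen-bond donor and 1 hydrogen-bond acceptor, so this result covers a change of chain shape and ring content with those counts held equal, and the step stays within the scatter, whereas the exchange on the oxygen on an aromatic ring gives a 2.5-fold higher number from compound 1 to compound 2 (0.40 log units; beyond the scatter), beyond it. Nothing available explains why the read-out stays within the scatter at this place.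

From the compounds shown here alone, it remains open whether a chain ending in an amine or a carboxylic acid, or a longer chain, would also stay within the scatter at this place, since the two groups compared here match in their donor and acceptor counts. Going by these compounds, it is also open whether the same exchange on the amide chain would read the same with propyl rather than trifluoromethyl on the oxygen.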